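The source may hold more compounds than are shown below. What is called first, only, known or untested is meant among the compounds shown, and "the series" means these compounds.

In a functional assay on Hs-578T cells (Homo sapiens) for inhibition, read by sulforhodamine B assay, with a stated time of 48 h, tested at 10 uM (on this read-out lower numbers stand for less inhibition and higher numbers for more inhibition at the one concentration tested (going by the name of the read-out)), compound 2 `Fc1ccc(-c2cn3ccnc3c(-c3ccc4ncn(C5CCCCC5)c4c3)n2)cc1` gives 17.6%. Among the three measured compounds it stands second highest: compound 1 `Brc1cn2ccnc2c(-c2ccc3ncn(C4CCCCC4)c3c2)n1` gives 16.1%, with a number 1.5 percentage points higher from compound 1 to compound 2 (within the scatter), and compound 3 `Brc1ccc(-c2cn3ccnc3c(-c3ccc4ncn(C5CCCCC5)c4c3)n2)cc1` gives 24.5%, with a number 6.9 percentage points higher from compound 2 to compound 3 (within the scatter). The remaining step, a number 8.4 percentage points higher from compound 1 to compound 3 (within the scatter), is likewise within the scatter. Compound 4 `Fc1ccccc1-c1cn2ccnc2c(-c2ccc3ncn(C4CCCCC4)c3c2)n1` differs from compound 2 in one place: 2-fluorophenyl in place of 4-fluorophenyl on an aromatic carbon. No measured step exchanges 4-fluorophenyl for 2-fluorophenyl; the three steps shown concern bromo, 4-fluorophenyl and 4-bromophenyl at the same aromatic carbon, and all lie within the scatter, so no step beyond the scatter is expected here either. Compound 4 is therefore estimated at 18%, between 8% and 30%. This amounts to an expected a number 0.4 percentage points higher from compound 2 to compound 4 (within the scatter).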

Compound 4, a percentage reported as inhibition, at one concentration (the size of the read-out at that concentration, not a potency): 5.26%
Estimate against measurement, compound 4: 12.7 percentage points above, outside the stated range (below it).
By their numbers in this assay, from the lowest: compound 4; then compounds 1, 2 and 3 (each within the scatter of the next).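

Every earlier step at this aromatic carbon stayed within the scatter, but in this assay the change to 2-fluorophenyl gives a number 12.3 percentage points lower from compound 2 to compound 4 (beyond the scatter) even though the two compounds have the same atoms, joined differently. The other two steps are also beyond the scatter, namely a number 19.2 percentage points lower from compound 3 to compound 4 (beyond the scatter) and a number 10.8 percentage points lower from compound 1 to compound 4 (beyond the scatter), so the place of the fluorine on this phenyl ring matters here. Nothing available explains this result. The compounds shown leave open whether 2-chlorophenyl or 2-methoxyphenyl would behave like 2-fluorophenyl.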